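Replacing the Acetyl on the Ring Nitrogen: Expected Effect

A few compounds are considered here, and "the series" means these few. Any claim that something is new, unique, unknown or untested is made for them only; others in the source may bear on it.

Compound 1, `CC(=O)N1N=C(c2ccc(N3CCN(C)CC3)cc2)CC1c1ccc(N(C)C)cc1`: -1%
Compound 2, `CN1CCN(c2ccc(C3=NN(C(=O)CCCl)C(c4ccc(N(C)C)cc4)C3)cc2)CC1`: 2.4%

In a functional assay on MDA-MB-231 cells (Homo sapiens) for inhibition, read by sulforhodamine B assay, tested at 10 uM (a lower number here means less inhibition, a higher number more inhibition at the concentration tested (going by the name of the read-out)), compound 1 gives -1%, and compound 2 gives 2.4%. Going by the values given here, compound 1 holds the lowest of the two numbers, but the only step measured, a number 3.4 percentage points higher from compound 1 to compound 2 (within the scatter), stays within the scatter, so the two compounds cannot be ranked against each other.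

Compound 3, `CN1CCN(c2ccc(C3=NN(S(=O)(=O)c4ccc(C#N)cc4)C(c4ccc(N(C)C)cc4)C3)cc2)CC1`, differs from compound 1 in one place: (4-cyanophenyl)sulfonyl in place of acetyl on an amine nitrogen in a ring. Among the compounds with values here, the single measured step concerns a small alteration on the saturated chain attached to the carbonyl and does not touch the acetyl group itself, so no measured step bears directly on this exchange. Both measured compounds sit near zero inhibition. Compound 3 is therefore expected to stay at a similar level, with an estimated step of a number 6 percentage points higher from compound 1 to compound 3 (within the scatter) that does not exceed the scatter. The estimate for compound 3 is 5%, with a range from -10% to 25%.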

Compound 3, a percentage reported as inhibition, at one concentration (the size of the read-out at that concentration, not a potency): 99.8%
Beside the measured number, compound 3's estimate is 94.8 percentage points below it; measured number outside the range, above it.
By their numbers in this assay, from the lowest: compounds 1 and 2 (each within the scatter of the next); then compound 3.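

In this assay the group on this ring nitrogen can change the result greatly: (4-cyanophenyl)sulfonyl in place of acetyl gives a number 100.8 percentage points higher from compound 1 to compound 3 (beyond the scatter) and the same group in place of (2-chloroethyl)carbonyl gives a number 97.4 percentage points higher from compound 2 to compound 3 (beyond the scatter) on the same core. Going by these compounds alone, the earlier pair differed only in a small change to the chain on the carbonyl and stayed within the scatter, so only this exchange shows that the position can move the read-out at all. Nothing available here explains the size of this step.

The exchange replaces the carbonyl with a sulfonyl and also brings in an aromatic ring carrying a nitrile, so the compounds shown cannot tell which of these parts matters. A methanesulfonyl group, with no ring, or a benzoyl group, with no sulfonyl, would help to separate them.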